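This account rests on a few compounds, and the source may have more. Where it says the series, first, only, none or still open, it means among the compounds named here.

Working notes on the series, read in an ADME assay on the whole organism (Rattus norvegicus, strain Lewis) for metabolic stability, at a dose of 2 mg/kg by the oral route; on this read-out lower numbers stand for a shorter-lived compound and higher numbers for a longer-lived compound. Compound 1 `COc1ccccc1SC[C@@H]1CCc2cc([C@H]3CC[C@](N)(CO)C3)ccc2C1` gives 24 h, compound 2 `Cc1ccc(OC[C@@H]2CCc3cc([C@H]4CC[C@](N)(CO)C4)ccc3C2)cc1` gives 35 h and compound 3 `COc1cccc(OC[C@@H]2CCc3cc([C@H]4CC[C@](N)(CO)C4)ccc3C2)c1` gives 24 h. Compound 3 is level with compound 1, and all three values lie within the scatter of one another.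

The next entry is compound 4 `COc1cccc(SC[C@@H]2CCc3cc([C@H]4CC[C@](N)(CO)C4)ccc3C2)c1`, with (3-methoxyphenyl)sulfanyl in place of 3-methoxyphenoxy on a saturated chain carbon bound to a saturated ring carbon.

Among the measured compounds shown here, no measured pair isolates this exchange of sulfur for oxygen. The closest evidence is no change at the digits printed from compound 1 to compound 3 (within the scatter), although that step also exchanges the 2-methoxyphenyl for the 3-methoxyphenyl arrangement. Also relevant are a 1.5-fold higher number from compound 1 to compound 2 (0.16 log units; within the scatter) and a 1.5-fold lower number from compound 2 to compound 3 (0.16 log units; within the scatter). For the measured compounds named here, no step so far leaves the scatter, so none beyond the scatter is expected in this assay.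

The expected result is no change at the digits printed from compound 3 to compound 4 (within the scatter). Compound 4 is estimated at 24 h, with an expected range of 13 h to 42 h.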

Compound 4, half-life: 21 h
The estimate for compound 4 lay 1.1-fold (0.06 log units) above the measured number, within the range that was stated.
By their numbers in this assay, from the lowest: compounds 4, 1, 3 and 2 (each within the scatter of the next).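

In this assay, among the compounds shown here, the first isolated exchange of sulfur for oxygen at this place, on a saturated chain carbon bound to a saturated ring carbon, gives a 1.1-fold lower number from compound 3 to compound 4 (0.06 log units; within the scatter) and stays within the scatter. With sulfur held constant, 3-methoxyphenyl in place of 2-methoxyphenyl gives a 1.1-fold lower number from compound 1 to compound 4 (0.06 log units; within the scatter), while (3-methoxyphenyl)sulfanyl in place of 4-methylphenoxy gives a 1.7-fold lower number from compound 2 to compound 4 (0.22 log units; within the scatter), so neither step separates these compounds beyond the scatter. Nothing measured here offers an explanation for these small steps.

From the compounds shown here alone, the four compounds cover only methoxy- or methyl-substituted phenyl groups joined through oxygen or sulfur, so the tolerance of this place to wider change remains open. Whether a carboxylic acid, a primary amine or a longer chain in place of these aryl groups would move the half-life beyond the scatter is also unresolved.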